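The source may report more compounds than this note shows. Statements on the series, on what has been measured and on what is new or still open speak of the compounds shown alone.

Of the compounds shown here, three that share one core have been measured in an assay on CHO cells with metabotropic glutamate receptor 5 (Homo sapiens) as the target; on this read-out lower numbers stand for an effect already at smaller amounts and higher numbers for an effect only at larger amounts of compound. Compound 1 `O=C(Nc1cc(-c2ccccc2)nn1-c1ccccc1)c1ccc(F)c(F)c1` gives 10 nM. Compound 2 `Cc1ccc(C(=O)Nc2cc(-c3ccccc3)nn2-c2ccccc2)cc1` gives 30 nM, and the step of a 3.0-fold higher number from compound 1 to compound 2 (0.48 log units; beyond the scatter) is the only one here that goes beyond the scatter. Compound 3 `O=C(Nc1cc(-c2ccccc2)nn1-c1ccccc1)c1cccc(F)c1` gives 20 nM; it stands second highest of the three, with compound 2 nearest and compound 1 furthest, both within the scatter, as the steps of a 1.5-fold lower number from compound 2 to compound 3 (0.18 log units; within the scatter) and a 2.0-fold higher number from compound 1 to compound 3 (0.30 log units; within the scatter) show.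

Compound 4 `O=C(Nc1cc(-c2ccccc2)nn1-c1ccccc1)c1ccsc1` is not yet measured. It differs from compound 3 by thiophen-3-yl in place of 3-fluorophenyl on a carbonyl carbon. The two steps that bear on it, both changes of the ring on the carbonyl carbon, were a 3.0-fold higher number from compound 1 to compound 2 (0.48 log units; beyond the scatter) and a 1.5-fold lower number from compound 2 to compound 3 (0.18 log units; within the scatter): one modest, one within the scatter. A ring swap at this place has so far moved the number little, so for compound 4 the step of a 1.5-fold higher number from compound 3 to compound 4 (0.18 log units; within the scatter) in this assay is expected to be small, likely within the scatter. The estimate for compound 4 is therefore 30 nM, with a range from 10 nM to 100 nM.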

Compound 4, half-maximal effective concentration: 1800 nM
Compound 4: the middle estimate sits 60-fold (1.78 log units) below what was measured; the whole stated range lies below it.
By their numbers in this assay, from the lowest: compounds 1, 3 and 2 (each within the scatter of the next, the first and the last beyond it); then compound 4.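

In this assay, among the compounds shown here, the ring on the carbonyl carbon proves far less forgiving than the earlier compounds suggested: thiophen-3-yl in place of 3-fluorophenyl gives a 90-fold higher number from compound 3 to compound 4 (1.95 log units; beyond the scatter) as the step, while the other two rings give a 60-fold higher number from compound 2 to compound 4 (1.78 log units; beyond the scatter) and a 180-fold higher number from compound 1 to compound 4 (2.26 log units; beyond the scatter) as theirs. Among compounds 1, 2 and 3, the swaps between substituted phenyl rings gave steps that were modest at most, so the exchange of a six-membered ring of carbon only for a five-membered aromatic ring with one hetero atom is the first change at this place to produce a large step. Nothing measured here accounts for the size of this step.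

The compounds shown leave open whether the step follows from the smaller ring, from its sulfur or from the loss of the fluoro or methyl group. Plain phenyl, furan-3-yl or a methyl-bearing thiophen-3-yl on the same carbonyl carbon would begin to separate these readings.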